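The source may hold more compounds than are shown below. What is called first, only, known or untested is meant among the compounds shown, and "the series" means these compounds.

Compounds measured so far:
- compound 1, `C=C(c1ccc(Cl)cc1Cl)C1COC(C)(C)OO1`: 92600 nM
- compound 2, `C=C(c1ccc(Cl)cc1Cl)C1COC2(CCCCC2)OO1`: 810 nM
- compound 3, `C=C(c1ccc(F)c(F)c1)C1COC2(CCCCC2)OO1`: 7880 nM

Three compounds share a core carrying a substituted phenyl on a terminal alkene. In a functional assay on A549 cells (Homo sapiens) for inhibition, read by MTT assay, with a stated time of 72 h (on this read-out lower numbers stand for stronger inhibition and higher numbers for weaker inhibition), compound 1 gives 92600 nM, the highest of the three numbers. Its nearest neighbour is compound 3, whose value of 7880 nM lies beyond the scatter from it, and compound 2, with 810 nM, lies furthest away. Compound 1 thus shows the weakest inhibition of the set.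

Compound 4, `C=C(c1ccc(Cl)c(Cl)c1Cl)C1COC(C)(C)OO1`, has not yet been measured. It differs from compound 1 in a single place: chloro in place of hydrogen on an aromatic carbon. Among the measured compounds shown here, no pair of measured compounds shows this same change, so its effect in this assay cannot be read from the data at hand; the phenyl substitution pattern and the peroxide ring both vary among compounds 2 and 3 at once.

For compound 4 the step of a 1.5-fold lower number from compound 1 to compound 4 (0.19 log units; within the scatter) is expected to be small, within or only just beyond the scatter, and slightly toward stronger inhibition. Compound 4 is therefore estimated at 60000 nM in this assay, with a range from 20000 nM to 200000 nM.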

Compound 4, half-maximal inhibitory concentration: 52100 nM
Compound 4: the middle estimate sits 1.2-fold (0.06 log units) above what was measured; measured number inside the range.
By their numbers in this assay, from the lowest: compound 2; then compound 3; then compounds 4 and 1 (each within the scatter of the next).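

In this assay, chloro in place of hydrogen on this aromatic carbon, ortho to two chloro groups and meta to a large group, gives a 1.8-fold lower number from compound 1 to compound 4 (0.25 log units; within the scatter). Among the compounds shown here, this is the first comparison in the set between compounds that differ in one place, and it shows that this added chloro moves the number no further than the usual scatter of repeated measurements. Nothing at hand offers an explanation for this small step.

The compounds shown leave open whether the same change would stay this small on the core of compound 2, which carries a different group on the peroxide ring. They also leave open what an amine, a methoxy group or a carboxylic acid would do on this aromatic carbon in place of chloro.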